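From 2,3-dichlorophenyl to 2-fluorophenyl on the shared core

The compounds below may be only part of what the source reports. "The series", "measured", "known", "first", "only" and "open" are said of these compounds alone.

Of the compounds shown here, three sharing one core have been measured in a functional assay on WM1361 cells (Homo sapiens) for inhibition, read by MTT assay, with a stated time of 24 h; a lower number here means a stronger inhibitor, a higher number a weaker inhibitor. There, compound 1 `O=c1oc2ccccc2c(N2CCN(c3cccc(Cl)c3Cl)CC2)c1CO` gives 45900 nM, and compound 3 `O=c1oc2ccccc2c(N2CCN(C(c3ccc(F)cc3)c3ccc(F)cc3)CC2)c1CO` gives 29400 nM. These two numbers lie within the scatter of each other, so neither can be ranked above the other. Compound 2 `O=c1oc2ccccc2c(N2CCN(c3ccccc3)CC2)c1CO` returns only a limit, > 50000 nM.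

The next compound to be tested is compound 4 `O=c1oc2ccccc2c(N2CCN(c3ccccc3F)CC2)c1CO`, which keeps the core of compound 1 and carries 2-fluorophenyl in place of 2,3-dichlorophenyl on an amine nitrogen in a ring.

For the measured compounds named here, one measured step bears directly on this change, since it replaces the same 2,3-dichlorophenyl with phenyl at the same place. That step is an at least 1.0-fold higher number from compound 1 to compound 2 (0.03 log units; that floor lies within the scatter). As far as these compounds go, its true size remains open, as it rests on a limit. Given this step to compound 2, no step beyond the scatter is expected in this assay, though any drift would more likely be towards a higher number. The expected step is a 1.0-fold higher number from compound 1 to compound 4 (0.00 log units; within the scatter). For compound 4 the estimated value is 46000 nM, with an expected range from 27000 nM to 50000 nM.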

Compound 4, half-maximal inhibitory concentration: > 50000 nM
Compound 4: a limit, no number; the forecaster's own chance of this, stated with the estimate: 45%; at least 1.0-fold (0.03 log units) between middle value and limit.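

In this assay the new result is again only a limit, so the change to 2-fluorophenyl on an amine nitrogen in a ring can be read only as a floor, and that floor lies within the scatter: an at least 1.0-fold higher number from compound 1 to compound 4 (0.03 log units; that floor lies within the scatter). The step from compound 2 to compound 4, fluoro in place of hydrogen on an aromatic carbon, cannot be read, as both ends of it are limits. What this result adds is that a second replacement of 2,3-dichlorophenyl at this place also gives no number that can be set against compound 1, so the two replacements shown cannot be ranked against each other: the limit of > 50000 nM in this assay, at which 2 of the 4 values shown sit.

As far as these compounds go, how far the true values of compound 2 and compound 4 lie from compound 1 remains open, and so does whether the fluoro group has any effect in this assay. Also open, from the compounds shown here alone, is whether a different group on the same amine nitrogen, such as a methoxyphenyl or a pyridine ring, would return a number rather than a limit, and so give this position a readable step.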